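A few compounds are considered here, and "the series" means these few. Any claim that something is new, unique, unknown or untested is made for them only; others in the source may bear on it.

Measured compounds:
compound 1, `CCC1=C(O)c2c(oc(-c3ccc(C)cc3)cc2=O)C(CC)(CC)C1=O`, 0.08 uM
compound 2, `CCCc1ccc(-c2cc(=O)c3c(o2)C(CC)(CC)C(=O)C(CC)=C3O)cc1`, 12.2 uM
compound 3, `CCC1=C(O)c2c(oc(-c3ccc(CBr)cc3)cc2=O)C(CC)(CC)C1=O`, 27.9 uM

In a functional assay on KBVIN cells (Homo sapiens) for antiproliferative activity, read by sulforhodamine B assay, with a stated time of 3 days (a higher number here means that more compound is needed for the effect, a lower number that less compound is needed), compound 2 gives the second highest of the three numbers; compound 3 lies nearest, and compound 1 furthest. Compound 4, `CCC1=C(O)c2c(oc(-c3cccc(F)c3)cc2=O)C(CC)(CC)C1=O`, has not been measured. It differs from compound 2 in one place: 3-fluorophenyl in place of 4-propylphenyl on an aromatic carbon. The measured steps all concern the saturated chain carbon bound to the aromatic ring, and none touches a fluorine or the ring position used in compound 4. The step of a 150-fold higher number from compound 1 to compound 2 (2.18 log units; beyond the scatter) shows that lengthening that chain raised the number strongly, and a 350-fold higher number from compound 1 to compound 3 (2.54 log units; beyond the scatter) and a 2.3-fold higher number from compound 2 to compound 3 (0.36 log units; beyond the scatter) point the same way for a bromo group there. For the measured compounds named here, removing the propyl chain altogether, as in compound 4, would therefore be expected to move the number back toward compound 1, though the fluorine itself has no measured precedent. The step of a 24-fold lower number from compound 2 to compound 4 (1.39 log units; beyond the scatter) is thus expected to be a large fall in the number. Compound 4 is estimated at 0.5 uM, with a range from 0.05 uM to 5 uM.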

Compound 4, concentration for half-maximal effect: 3.09 uM
The estimate for compound 4 lay 6.2-fold (0.79 log units) below the measured number, within the range that was stated.
By their numbers in this assay, from the lowest: compound 1; then compound 4; then compound 2; then compound 3.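

In this assay, 3-fluorophenyl at this place gives a 3.9-fold lower number from compound 2 to compound 4 (0.60 log units; beyond the scatter) and a 9.0-fold lower number from compound 3 to compound 4 (0.96 log units; beyond the scatter), so the number can fall from those of the two longer 4-substituted phenyl groups when the whole aryl group is exchanged. Even so, the change gives a 39-fold higher number from compound 1 to compound 4 (1.59 log units; beyond the scatter), so among these four compounds the 4-methylphenyl group keeps the lowest number, and losing the propyl chain does not by itself restore it. No measurement given here explains these shifts.

Each step to compound 4 changes both the group on the phenyl ring and where it sits, so the effects of the fluorine and of its position cannot be separated. On these data alone, how plain phenyl, 4-fluorophenyl or a phenyl carrying an amine would compare remains open.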